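Removing the side chain of compound 1: cytotoxicity notes

The compounds below may be only part of what the source reports. "The series", "measured", "known", "first", "only" and "open" are said of these compounds alone.

Measured so far:
compound 1 `C=CC(C)(C)c1[nH]c2ccc(C[C@H](O)C(C)(C)OC)cc2c1/C=C1\NC(=O)[C@H](C)NC1=O` — in an ADME assay on MDCK cells (Canis lupus familiaris) for cytotoxicity, read by CellTiter-Glo, with a stated time of 40 h (a higher number here means that more compound is tolerated, a lower number that less compound is tolerated), compound 1 gives only the assay limit, > 200000 nM.
compound 2 `C=CC(C)(C)c1[nH]c2ccccc2c1/C=C1\NC(=O)[C@@](CO)(OC)NC1=O` — in this assay compound 2 likewise gives only the limit, > 200000 nM.
compound 3 `C=CC(C)(C)c1[nH]c2ccc(C[C@H](O)C(C)(C)O)cc2c1/C=C1\NC(=O)C(=O)NC1=O` — in this assay compound 3 also gives only the limit, > 200000 nM.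

Where compound 1 stands: there is no number for it, only a limit, and the same holds for the two others; all three values sit at the limit of > 200000 nM in this assay, at which 3 of the 3 values shown sit. No ordering among compounds 1, 2 and 3 can be drawn from this, and nothing separates them within the scatter of the method.

The next compound, compound 4 `C=CC(C)(C)c1[nH]c2ccccc2c1/C=C1\NC(=O)[C@H](C)NC1=O`, differs from compound 1 in one place: hydrogen in place of 2-hydroxy-3-methoxy-3-methylbutyl on an aromatic carbon. The change is the loss of the 2-hydroxy-3-methoxy-3-methylbutyl group from an aromatic carbon of the shared core.

Within the data shown here, no measured step in this assay is available, so the size of this step is open. Given that compound 2 and compound 3 carry quite different substitution from compound 1 and still report only the limit, no step beyond the scatter is expected, in either direction. Compound 4 is expected at 200000 nM, within 100000 nM to 400000 nM, most likely again as a limit. The step of a number no higher from compound 1 to compound 4 (the limit leaves the size open) is thus estimated to be nil.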

Compound 4, half-maximal cytotoxic concentration: > 200000 nM
Compound 4: no number, only a limit (the forecaster's own chance of this, stated with the estimate: 85%); the middle value lies on the limit itself.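

In this assay, among these compounds, compound 4 gives only a limit, > 200000 nM, as compound 1 does, so no step between the two can be read. The compounds shown leave open what concentration of any of them is cytotoxic, and whether losing the 2-hydroxy-3-methoxy-3-methylbutyl group changes this at all, because every value stands at one limit: the limit of > 200000 nM in this assay, at which 4 of the 4 values shown sit.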